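A few compounds are considered here, and "the series" means these few. Any claim that something is new, unique, unknown or untested is made for them only; others in the source may bear on it.

Values in a functional assay on HCT-116 cells (Homo sapiens) for antiproliferative activity, read by MTT assay, with a stated time of 72 h; on this read-out lower numbers stand for stronger inhibition and higher numbers for weaker inhibition:
- Compound 1 `C=CC(=O)N(Cc1ccccc1)c1nc(-c2ccccc2)cs1`: > 30000 nM (a limit of the assay)
- Compound 2 `C=CC(=O)N(CC(=O)OC(C)(C)C)c1nc(-c2ccccc2)cs1`: 20900 nM
- Compound 3 `C=CC(=O)N(CC(=O)NC1CCCCC1)c1nc(-c2ccccc2)cs1`: >= 29300 nM (a limit of the assay)
- Compound 4 `C=CC(=O)N(CC(=O)N1CCOCC1)c1nc(-c2ccccc2)cs1`: not yet measured

Compound 3 gives >= 29300 nM, which is a limit and not a number. Compound 1 gives > 30000 nM, which is also a limit. For the measured compounds named here, compound 2, at 20900 nM, holds the only actual number in the set, so the position of compound 3 is only loosely fixed.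

The next change puts morpholin-4-yl in place of cyclohexylamino on a carbonyl carbon.

The closest measured precedent changes the same carbonyl carbon, where cyclohexylamino in place of tert-butoxy gave an at least 1.4-fold higher number from compound 2 to compound 3 (0.14 log units; that floor lies within the scatter). The change on the saturated chain carbon gave an at least 1.4-fold lower number from compound 1 to compound 2 (0.15 log units; that floor lies within the scatter) and bears on it less directly. Going by the values given here, neither step is a full measured size, and no compound with morpholin-4-yl has been measured so far.

With an at least 1.4-fold higher number from compound 2 to compound 3 (0.14 log units; that floor lies within the scatter) as the nearest guide, no step beyond the scatter is expected in this assay, and no direction can be favoured. The expected step is a number no higher from compound 3 to compound 4 (the limit leaves the size open). The estimate for compound 4 is 29000 nM, with an expected range from 14000 nM to 60000 nM.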

Compound 4, half-maximal inhibitory concentration: 14600 nM
Estimate against measurement, compound 4: 2.0-fold (0.30 log units) above; measured number inside the range.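

In this assay, morpholin-4-yl in place of cyclohexylamino on the carbonyl carbon gives an at least 2.0-fold lower number from compound 3 to compound 4 (0.30 log units; that floor lies within the scatter); this is a floor and not a full size, with compound 3 read only as a limit: the limit of >= 29300 nM in this assay, at which 1 of the 4 values shown sits. Morpholin-4-yl in place of tert-butoxy at the same place gives a 1.4-fold lower number from compound 2 to compound 4 (0.16 log units; within the scatter), so compound 2 and compound 4 cannot be told apart in this assay, and an actual number at this position now exists for an amide as well as for the tert-butyl ester. For the compounds shown here, the only new step that clears the scatter is an at least 2.0-fold lower number from compound 1 to compound 4 (0.31 log units; beyond the scatter), with (morpholin-4-yl)carbonyl in place of phenyl on the saturated chain carbon, and it too is a floor, with compound 1 read only as a limit: the limit of > 30000 nM in this assay, at which 1 of the 4 values shown sits.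

From the compounds shown here alone, what compound 1 and compound 3 would give as actual numbers stays open, and with it the true size of both steps that start from them. Also open, going by these compounds, is whether piperazin-1-yl on the same carbonyl carbon, or a free carboxylic acid in place of the tert-butyl ester, would move the number beyond the scatter from compound 4.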